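Adding an acetyl group to compound 1

The compounds below may be only part of what the source reports. "The series", "measured", "known", "first", "only" and "open" are said of these compounds alone.

- compound 1 `O=C1C=CC[C@@H]([C@H](O)[C@H](O[C@@H](c2ccccc2)[C@@H](O)[C@@H]2CC=CC(=O)O2)c2ccccc2)O1`: 7100 nM
- compound 2 `O=C1C=CC[C@@H]([C@H](O)[C@@H](O[C@H]([C@@H]2CC=CC(=O)O2)[C@@H](O)c2ccccc2)c2ccccc2)O1`: 9500 nM

In a functional assay on NCI-H1299 cells (Homo sapiens) for cytotoxicity, read by luminescence and CellTiter-Glo, with a stated time of 72 h (on this read-out higher numbers stand for weaker inhibition and lower numbers for stronger inhibition), compound 1 and compound 2 lie within the usual scatter of repeated measurements, so the numbers do not separate them. Compound 3 `CC(=O)O[C@@H]([C@@H]1CC=CC(=O)O1)[C@H](O[C@@H](c1ccccc1)[C@@H](O)[C@@H]1CC=CC(=O)O1)c1ccccc1` carries one change from compound 1: acetyl in place of hydrogen on an oxygen on a saturated carbon. This places acetyl in place of hydrogen on an oxygen on a saturated carbon, turning hydroxy to acetoxy. Going by the values given here, no measured pair shows this change, so no shift beyond the scatter is expected in this assay. The expected step of a 1.2-fold lower number from compound 1 to compound 3 (0.07 log units; within the scatter) is therefore small. For compound 3, the estimated value is 6000 nM, with an expected range of 2000 nM to 20000 nM.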

Compound 3, half-maximal inhibitory concentration: 4600 nM
Estimate against measurement, compound 3: 1.3-fold (0.12 log units) above; measured number inside the range.
By their numbers in this assay, from the lowest: compounds 3, 1 and 2 (each within the scatter of the next, the first and the last beyond it).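

Turning hydroxy to acetoxy on this oxygen on a saturated carbon gives a 1.5-fold lower number from compound 1 to compound 3 (0.19 log units; within the scatter) in this assay, so the numbers do not separate the two compounds. The hydrogen on this oxygen can therefore be replaced by acetyl with the number staying within the scatter, which compounds 1 and 2 alone could not show. No measurement at hand offers a reason for this result. From the compounds shown here alone, whether a longer chain such as butanoyl, or a simple methyl ether, would behave the same way on this oxygen remains open. So does the effect of acetyl on the remaining hydroxy of compound 3.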